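Swapping Methyl for Chloro on a Pyrazolopyrimidinone Anti-inflammatory

The source may hold more compounds than are shown below. What is called first, only, known or untested is meant among the compounds shown, and "the series" means these compounds.

Compound 3 `Cc1ccc(Nc2nn(-c3ccc(S(N)(=O)=O)cc3)c3nc(Nc4ccccc4)n(-c4ccccc4)c(=O)c23)cc1` holds the highest number of the three measured compounds in a functional assay on the whole organism (strain Wistar albino) for inhibition, with Rattus norvegicus as the target, read by paw edema, with a stated time of 1 h, at a dose of 25 mg/kg by the oral route (a lower number here means less inhibition, a higher number more inhibition at the dose given (going by the name of the read-out)), giving 77%. Compound 1 `NS(=O)(=O)c1ccc(-n2nc(Nc3ccccc3)c3c(=O)n(-c4ccccc4)c(Nc4ccccc4)nc32)cc1` gives 60.2%, and compound 2 `Cc1ccc(Nc2nn(-c3ccccc3)c3nc(Nc4ccccc4)n(-c4ccccc4)c(=O)c23)cc1` gives 55.7%. The gaps are a number 16.8 percentage points higher from compound 1 to compound 3 (beyond the scatter) and a number 21.3 percentage points higher from compound 2 to compound 3 (beyond the scatter). Compound 4 `NS(=O)(=O)c1ccc(-n2nc(Nc3ccc(Cl)cc3)c3c(=O)n(-c4ccccc4)c(Nc4ccccc4)nc32)cc1` differs from compound 3 by chloro in place of methyl on an aromatic carbon. Among the measured compounds shown here, no measured step exchanges one small group for another at this place; the only related step is the addition of methyl, seen in a number 16.8 percentage points higher from compound 1 to compound 3 (beyond the scatter), where the number in this assay is higher with the methyl present. Compound 4 is therefore expected to stay close to compound 3, with an estimated step of a number 5 percentage points lower from compound 3 to compound 4 (within the scatter) within the scatter. The estimate for compound 4 in this assay is 72%, between 58% and 85%.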

Compound 4, a percentage reported as inhibition, in the whole organism at one dose (the size of the read-out at that dose, not a potency): 69.8%
The estimate for compound 4 lay 2.2 percentage points above the measured number, and the stated range covers the measured number.
By their numbers in this assay, from the lowest: compounds 2, 1, 4 and 3 (each within the scatter of the next, the first and the last beyond it).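

In this assay the change from methyl to chloro at this position gives a number 7.2 percentage points lower from compound 3 to compound 4 (within the scatter) and so cannot be told apart from the usual scatter. Against hydrogen at the same place, chloro gives a number 9.6 percentage points higher from compound 1 to compound 4 (within the scatter) while methyl gives a number 16.8 percentage points higher from compound 1 to compound 3 (beyond the scatter) and only the methyl step clears the scatter. Nothing available explains either step.

On these data alone, whether a methoxy group or an amine at this position would keep the number in the same range remains open. So does whether chloro would behave the same way on the compounds without the sulfamoyl group.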